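Trifluoromethyl for iodo: expectation for compound 3

The source may hold more compounds than are shown below. What is called first, only, known or untested is meant among the compounds shown, and "the series" means these compounds.

Compound 1 `NC(=O)c1c(NC(=O)c2ccccc2Cl)sc2c1CCN(C(=S)Nc1ccccc1Br)C2` gives 24600 nM in a functional assay on HeLa cells (Homo sapiens) for antiproliferative activity, with a stated time of 24 h; a higher number here means a weaker inhibitor, a lower number a stronger inhibitor. Compound 2 `NC(=O)c1c(NC(=O)c2ccccc2Cl)sc2c1CCN(C(=S)Nc1ccccc1I)C2` gives 29000 nM in this assay, the higher of the two numbers measured, although a 1.2-fold higher number from compound 1 to compound 2 (0.07 log units; within the scatter) sits within the scatter. Compound 3 `NC(=O)c1c(NC(=O)c2ccccc2Cl)sc2c1CCN(C(=S)Nc1ccccc1C(F)(F)F)C2` carries the change (trifluoromethyl in place of iodo on an aromatic carbon). Among the measured compounds shown here, the single measured step, a 1.2-fold higher number from compound 1 to compound 2 (0.07 log units; within the scatter), concerns an exchange of one halogen for another and bears on this step only loosely; it shows that a change at this place left this assay essentially unmoved. No step beyond the scatter is therefore expected, and compound 3 is estimated at 28000 nM, range 10000 nM to 80000 nM, a step of a 1.0-fold lower number from compound 2 to compound 3 (0.02 log units; within the scatter).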

Compound 3, half-maximal inhibitory concentration: 26700 nM
For compound 3 the middle estimate is 1.0-fold (0.02 log units) above the measured one; the measured number falls inside the stated range.
By their numbers in this assay, from the lowest: compounds 1, 3 and 2 (each within the scatter of the next).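

In this assay trifluoromethyl in place of iodo gives a 1.1-fold lower number from compound 2 to compound 3 (0.04 log units; within the scatter) and trifluoromethyl in place of bromo gives a 1.1-fold higher number from compound 1 to compound 3 (0.04 log units; within the scatter) with both steps within the scatter. On this aromatic carbon, ortho to a large group, the insensitivity therefore extends beyond an exchange of one halogen for another to a group with more heavy atoms. No measurement bears on the reason for this flat result. From the compounds shown here alone, whether an amine, a carboxylic acid or a longer chain at this place would move the number beyond the scatter remains open. Going by these compounds, whether changes elsewhere on the shared core would do so also remains open.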